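Removal of the hydroxypropyl chain from the amide nitrogen

The source may hold more compounds than are shown below. What is called first, only, known or untested is meant among the compounds shown, and "the series" means these compounds.

Compound 3 `Cc1cc(/C=C/C#N)cc(C)c1Oc1cc(Nc2ccc(C#N)cc2)c(N)cc1C(=O)NCCCO` gives 3.22 in a physicochemical assay for lipophilicity, read by HPLC, measured as octanol-water partition, with a stated time of 24 h, at pH 7.4 (a higher number here means a more lipophilic compound, a lower number a more polar compound), the second highest of the three numbers measured. Compound 1 `CCNC(=O)c1cc(N)c(Nc2ccc(C#N)cc2)cc1Oc1c(C)cc(/C=C/C#N)cc1C` gives 3.63 in this assay, compound 2 `Cc1cc(/C=C/C#N)cc(C)c1Oc1cc(Nc2ccc(C#N)cc2)c(N)cc1C(=O)NN` gives 2.31. Compound 4 `Cc1cc(/C=C/C#N)cc(C)c1Oc1cc(Nc2ccc(C#N)cc2)c(N)cc1C(N)=O` differs from compound 3 by hydrogen in place of 3-hydroxypropyl on an amide-type nitrogen. Among the measured compounds shown here, two measured steps bear on it. The hydroxyl part of the chain is covered by a number 0.41 log units lower from compound 1 to compound 3 (beyond the scatter), which in reverse would raise the number. For the measured compounds named here, the loss of the remaining carbons has no direct counterpart; the nearest is a number 1.32 log units lower from compound 1 to compound 2 (beyond the scatter), where ethyl was exchanged for amino, and a number 0.91 log units higher from compound 2 to compound 3 (beyond the scatter). Taken together, the reversal of the hydroxyl step is expected to be outweighed by the loss of the three chain carbons, so a downward step beyond the scatter is expected. For compound 4 the estimate in this assay is 2.65, with a range of 2.2 to 3.1, which means an expected step of a number 0.57 log units lower from compound 3 to compound 4 (beyond the scatter).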

Compound 4, partition coefficient: 3.53
Compound 4: middle estimate off by 0.88 log units, on the low side, and the stated range ends below it.
By their numbers in this assay, from the lowest: compound 2; then compound 3; then compounds 4 and 1 (each within the scatter of the next).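

In this assay, taking the 3-hydroxypropyl off the amide-type nitrogen gives a number 0.31 log units higher from compound 3 to compound 4 (beyond the scatter), so at this position the number does not fall when the chain is lost. Hydrogen and ethyl on this nitrogen are not separated, with a number 0.10 log units lower from compound 1 to compound 4 (within the scatter), so across these two compounds the number does not follow the carbons carried on the nitrogen, while amino stands apart from hydrogen, with a number 1.22 log units higher from compound 2 to compound 4 (beyond the scatter). Nothing at hand explains these steps.

Among the compounds shown, the carbons of the 3-hydroxypropyl cannot be told apart from its hydroxyl, and a plain propyl on the same nitrogen would bear directly on that. As far as these compounds go, whether a longer alkyl chain, or a chain ending in an amine or a carboxylic acid, would stay level with ethyl and hydrogen remains open.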